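The compounds below may be only part of what the source reports. "The series", "measured", "known", "first", "only" and "open" are said of these compounds alone.

Measured so far in an assay on U-937 cells for inhibition of Fatty-acid amide hydrolase 1 (Homo sapiens), read by scintillation counting, with a stated time of 15 min; on this read-out higher numbers stand for weaker inhibition and lower numbers for stronger inhibition:
- compound 1 `Cc1ccc(C(=O)NC2CCCCCC2)c(=O)n1Cc1ccc(F)cc1`: the limit > 10000 nM, a limit of this assay, not a number
- compound 2 `Cc1c(Br)cc(C(=O)NC2CCCCCC2)c(=O)n1Cc1ccc(F)cc1`: 5900 nM
- compound 3 `Cc1nc(OCc2ccc(F)cc2)c(C(=O)NC2CCCCCC2)cc1Br`: the limit > 10000 nM, again only a limit

Compound 2 and compound 1 share a core; the difference between the core of compound 3 and that of compound 2 is not broken down here, the two having the same atoms joined differently. Compound 4 `Cc1ccc(C(=O)NC2CCCCCC2)c(OCc2ccc(F)cc2)n1` is still to be measured in this assay.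

One change occurs twice. From compound 2 to compound 1 it is hydrogen in place of bromo on an aromatic carbon and gave an at least 1.6-fold higher number from compound 2 to compound 1 (0.22 log units; that floor lies within the scatter). From compound 3 to compound 4 it is the same kind of change, (hydrogen in place of bromo on an aromatic carbon); here the place is para to a (4-fluorobenzyl)oxy group, whereas in the earlier pair it was meta to a 4-fluorobenzyl group and para to a group of 1 heavy atom. Two of the three values sit at the limit of > 10000 nM in this assay, at which 2 of the 3 values shown sit.

For compound 4 the step is expected to be a step that the limit leaves unreadable from compound 3 to compound 4, no more than a flat or weakening step, resting on compound 3 already sitting at its limit > 10000 nM and on the direction of an at least 1.6-fold higher number from compound 2 to compound 1 (0.22 log units; that floor lies within the scatter). Compound 4 is therefore estimated at 30000 nM, most likely reported only as a limit, within 10000 nM to 150000 nM.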

Compound 4, half-maximal inhibitory concentration: > 10000 nM
Compound 4 ended at the assay's limit; the forecaster's own chance of this, stated with the estimate: 90%; the middle value lies beyond the limit too.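

No step can be read from compound 3 to compound 4, as both end at a limit and not at a number: the limit of > 10000 nM in this assay, at which 3 of the 4 values shown sit.

The compounds shown leave open whether hydrogen in place of bromo on an aromatic carbon changes inhibition at all in the core of compound 3, where neither value gives a number to compare.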